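Trifluoromethyl for Isobutyl: Expected Cytotoxicity Step

This account rests on a few compounds, and the source may have more. Where it says the series, first, only, none or still open, it means among the compounds named here.

Compound 1 `CC(C)N(Cc1cccc(OCCCCCC(=O)O)c1)C(=O)c1ccc(-c2cccc(N(C)C)c2)cc1` was tested in an ADME assay on HEK293 cells (Homo sapiens) for cytotoxicity, read by CellTiter-Glo and resazurin assay, with a stated time of 72 h; a lower number here means that less compound is needed, a higher number that more compound is needed for the effect. In this assay compound 1 gives only a limit, > 26000 nM. Compound 2 `CC(C)COc1cccc(-c2ccc(C(=O)N(Cc3cccc(OCCCCCC(=O)O)c3)C(C)C)cc2)c1` likewise reaches only a limit in this assay, > 26000 nM. The step that the two limits leave unreadable from compound 1 to compound 2 is therefore unreadable, since (the limit of > 26000 nM in this assay, at which 2 of the 2 values shown sit). Compound 3 `CC(C)N(Cc1cccc(OCCCCCC(=O)O)c1)C(=O)c1ccc(-c2cccc(OC(F)(F)F)c2)cc1` differs from compound 2 by trifluoromethyl in place of isobutyl on an oxygen on an aromatic ring. Going by the values given here, no measured step bears on this change, and both values shown are limits, so there is no ground to expect a readable change. The step of a number no higher from compound 2 to compound 3 (the limit leaves the size open) is expected to lie within the scatter, with the limit again the likely outcome. Compound 3 is estimated at 26000 nM, with a range from 10000 nM to 60000 nM.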

Compound 3, half-maximal effective concentration: > 26000 nM
Compound 3 gave a limit, no number; the forecaster's own chance of this, stated with the estimate: 80%; the middle value lies on the limit itself.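

Going by these compounds alone, compound 3, like compound 1 and compound 2, gives only a limit in this assay, so no step among the three can be read: the limit of > 26000 nM in this assay, at which 3 of the 3 values shown sit.

The compounds shown leave open the concentration at which any of the three reaches a half-maximal effect, and whether the dimethylamino, isobutoxy and trifluoromethoxy compounds differ at all.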